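Swapping the benzyl for a dimethoxyphenyl on the triazole nitrogen

The source may hold more compounds than are shown below. What is called first, only, known or untested is meant among the compounds shown, and "the series" means these compounds.

The series shares a core carrying an indolyl-methyl amide and a phenethyl-bearing triazole. In an in vitro assay on LLC-PK1 cells for displacement of a labelled ligand from growth hormone secretagogue receptor type 1 (Homo sapiens) (on this read-out lower numbers stand for stronger inhibition and higher numbers for weaker inhibition), compound 3 `COc1ccc(Cn2c(CCc3ccccc3)nnc2[C@H](NC(=O)c2cnccn2)c2c[nH]c3ccccc23)cc1` gives 14 nM, the second highest of the three numbers. Compound 2 `COc1ccc(Cn2c(CCc3ccccc3)nnc2[C@H](NC(=O)c2cnccn2)c2c[nH]c3ccccc23)c(OC)c1` gives 5 nM in this assay, and compound 1 `COc1ccc(-n2c(CCc3ccccc3)nnc2[C@H](NC(=O)c2ccccn2)c2c[nH]c3ccccc23)c(OC)c1` gives 33 nM. Going by the values given here, the one single-point step available, hydrogen in place of methoxy on an aromatic carbon, gave a 2.8-fold higher number from compound 2 to compound 3 (0.45 log units; beyond the scatter), a modest loss.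

Compound 4 `COc1ccc(-n2c(CCc3ccccc3)nnc2[C@H](NC(=O)c2cnccn2)c2c[nH]c3ccccc23)c(OC)c1` differs from compound 3 by 2,4-dimethoxyphenyl in place of 4-methoxybenzyl on an aromatic nitrogen. The step from compound 2 to compound 3 bears on it in reverse, since a methoxy is regained, which alone would argue for a lower number. Compound 1, however, already carries the 2,4-dimethoxyphenyl on the ring nitrogen and gives 33 nM, no better than compound 3, though it differs from compound 4 in a second place too. Weighing both, compound 4 is expected to show a 1.1-fold higher number from compound 3 to compound 4 (0.03 log units; within the scatter), a change that stays near the scatter. The estimate for compound 4 in this assay is 15 nM, with a range from 5 nM to 45 nM.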

Compound 4, half-maximal inhibitory concentration: 300 nM
The estimate for compound 4 lay 20-fold (1.30 log units) below the measured number, outside the stated range (above it).
By their numbers in this assay, from the lowest: compound 2; then compound 3; then compound 1; then compound 4.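

In this assay the aromatic nitrogen proves far less forgiving than the methoxy step suggested: 2,4-dimethoxyphenyl in place of 4-methoxybenzyl costs much (a 21-fold higher number from compound 3 to compound 4 (1.33 log units; beyond the scatter)), and 2,4-dimethoxyphenyl in place of 2,4-dimethoxybenzyl, which keeps both methoxy groups, costs more still (a 60-fold higher number from compound 2 to compound 4 (1.78 log units; beyond the scatter)). The regained methoxy therefore does not offset the loss of the benzyl form at this position. The carbonyl substituent also matters once 2,4-dimethoxyphenyl occupies the nitrogen, since pyrazin-2-yl in place of pyridin-2-yl also raises the number (a 9.1-fold higher number from compound 1 to compound 4 (0.96 log units; beyond the scatter)), so compound 1 had masked the cost of this swap. No measurement at hand explains these losses. Still open, going by these compounds, is whether a longer chain carrying the same dimethoxyphenyl would hold or lower the number, and whether an amine on that ring would be tolerated. Also open, on these data alone, is how pyridin-2-yl behaves on the benzyl compounds.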